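A few compounds are considered here, and "the series" means these few. Any claim that something is new, unique, unknown or untested is made for them only; others in the source may bear on it.

Measured so far in a functional assay on T47D cells (Homo sapiens) for inhibition, read by sulforhodamine B assay, with a stated time of 48 h; a lower number here means a stronger inhibitor of growth, a higher number a weaker inhibitor of growth:
- compound 1 `Cc1ccc(C2=NN(c3ccc(S(C)(=O)=O)cc3)C(=O)CC2)cc1`: > 100000 nM (a limit)
- compound 2 `Cc1cc(O)ccc1C1=NN(c2ccc(S(C)(=O)=O)cc2)C(=O)CC1`: > 100000 nM (a limit)

Neither result is a true number. On these data alone, compound 2 stands at a limit of this assay, > 100000 nM, so its real position is unknown. Among the measured compounds shown here, the same holds for both compounds tested so far: the limit of > 100000 nM in this assay, at which 2 of the 2 values shown sit.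

Compound 3 `CCc1ccc(C2=NN(c3ccc(S(C)(=O)=O)cc3)C(=O)CC2)cc1` carries 4-ethylphenyl in place of 4-hydroxy-2-methylphenyl on a carbon with a double bond to nitrogen, next to the ring nitrogen: 4-ethylphenyl in place of 4-hydroxy-2-methylphenyl on a carbon with a double bond to nitrogen.

For the measured compounds named here, the only measured step that bears on this change is a step that the two limits leave unreadable from compound 1 to compound 2. It altered the same group on the shared core, but it has no readable size, so it offers no measure of how far such a change can move the result. The expectation therefore rests on compound 2 and its limit of > 100000 nM, and no step beyond the usual scatter is predicted in either direction. The step expected is a number no higher from compound 2 to compound 3 (the limit leaves the size open). For compound 3 the estimated value is 100000 nM, with an expected range of 30000 nM to 200000 nM, and a report of only a limit is the likeliest outcome.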

Compound 3, concentration for total growth inhibition: 93300 nM
Compound 3: middle estimate off by 1.1-fold (0.03 log units), on the high side; measured number inside the range.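

In this assay, among the compounds shown here, compound 3 gives 93300 nM, the first true number for a group on this carbon with a double bond to nitrogen. The earlier results, for compound 1 and compound 2, were limits only. The change to 4-ethylphenyl gives an at least 1.0-fold lower number from compound 2 to compound 3 (0.03 log units; that floor lies within the scatter), and adding a methyl to the 4-methylphenyl group of compound 1 gives an at least 1.0-fold lower number from compound 1 to compound 3 (0.03 log units; that floor lies within the scatter). Both steps are only floors, so the result shows that a 4-ethylphenyl group in this place can give a readable number, but not how far compound 3 truly lies from compound 1 or compound 2.

On these data alone, it remains open whether a longer chain, as in 4-propylphenyl, or a phenyl group carrying an amine or a carboxylic acid, would move the number in this place by more than the usual scatter. Any such comparison within this small set is also still held back by a limit that most of its results share: the limit of > 100000 nM in this assay, at which 2 of the 3 values shown sit.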